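Swapping the Thiazole for a Pyrazole on the Shared Core

The source may hold more compounds than are shown below. What is called first, only, known or untested is meant among the compounds shown, and "the series" means these compounds.

Of the compounds shown here, three built on one core have been tested in a functional assay on CHO cells for agonist activity at Alpha-1A adrenergic receptor (Homo sapiens), read by FLIPR and calcium flux; a lower number here means that less compound is needed, a higher number that more compound is needed for the effect. Compound 1 `c1ccc(-c2cccc3c2CCC3c2ncc[nH]2)nc1` gives 1150 nM. Compound 2 `Cn1ccc(-c2cccc3c2CCC3c2ncc[nH]2)n1`, which carries a 1-methyl-1H-pyrazol-3-yl group, gives > 1300 nM, and that is a limit of the assay rather than a number. Compound 3 `c1cc(-c2nccs2)c2c(c1)C(c1ncc[nH]1)CC2` gives 426 nM, the lowest of the two numbers in this assay; its nearest neighbour is compound 1, and the step of a 2.7-fold lower number from compound 1 to compound 3 (0.43 log units; beyond the scatter) lies beyond the scatter. Against compound 2 the comparison shows an at least 3.0-fold lower number from compound 2 to compound 3 (0.48 log units; beyond the scatter).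

Compound 4 `c1cc(-c2cn[nH]c2)c2c(c1)C(c1ncc[nH]1)CC2` has not yet been measured. It differs from compound 3 in one place: 1H-pyrazol-4-yl in place of 1,3-thiazol-2-yl on an aromatic carbon. Both measured steps bear on this change: each swapped the ring on that same aromatic carbon, and in each the 1,3-thiazol-2-yl group gave the lower number. Leaving the thiazole for another five-membered ring with two nitrogens, this time one with a hydrogen-bond donor, is therefore expected to push the number upward again, probably by a modest amount, and a limit instead of a number is a real possibility. For compound 4 the expected step is a 3.3-fold higher number from compound 3 to compound 4 (0.52 log units; beyond the scatter). Compound 4 is estimated at 1400 nM, with a range from 450 nM to 4500 nM.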

Compound 4, half-maximal effective concentration: 14 nM
Beside the measured number, compound 4's estimate is 100-fold (2.00 log units) above it, outside the stated range (below it).
By their numbers in this assay, from the lowest: compound 4; then compound 3; then compound 1. At a limit, above all of these: compound 2.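

Among the compounds shown here, this position is far more sensitive to the choice of ring than the earlier compounds showed, and a small exchange can produce a large change in this assay: a 30-fold lower number from compound 3 to compound 4 (1.48 log units; beyond the scatter). The 1,3-thiazol-2-yl and 1H-pyrazol-4-yl groups are both five-membered aromatic rings with the same number of heavy atoms, yet 1H-pyrazol-4-yl also stands well clear of the other two groups, with an 82-fold lower number from compound 1 to compound 4 (1.91 log units; beyond the scatter) and an at least 92-fold lower number from compound 2 to compound 4 (1.96 log units; beyond the scatter). The second of those two steps gives only a minimum size, since the result for compound 2 is a limit and not a number: the limit of > 1300 nM in this assay, at which 1 of the 4 values shown sits.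

Compound 4 is the only compound shown with a hydrogen-bond donor on this ring, but a single compound cannot establish whether that donor accounts for the gain. A methyl group on the pyrazole nitrogen of compound 4 would address that question directly, while an amine or a carboxylic acid on the same aromatic carbon would show how far the low number extends beyond five-membered aromatic rings.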